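Replacing 5-fluoropyridin-3-yl with 6-methoxypyridin-3-yl

The source may hold more compounds than are shown below. What is called first, only, known or untested is meant among the compounds shown, and "the series" means these compounds.

In an ADME assay (liver) for metabolic stability, with Liver microsome (Rattus norvegicus) as the target, using microsomes and NADPH, with a stated time of 30 min, tested at 1 uM (a higher number here means faster removal of the compound, a lower number slower removal), compound 1 `Nc1ccc(S(=O)(=O)N2CCN(c3ncc(C(O)(C(F)(F)F)C(F)(F)F)cc3Br)CC2)cn1` gives 32 mL.min-1.g-1, compound 2 `CC(C)(O)C#Cc1cc(C(O)(C(F)(F)F)C(F)(F)F)cnc1N1CCN(S(=O)(=O)c2ccc(N)nc2)CC1` gives 16 mL.min-1.g-1 and compound 3 `Nc1ccc(S(=O)(=O)N2CCN(c3ncc(C(O)(C(F)(F)F)C(F)(F)F)cc3-c3cncc(F)c3)CC2)cn1` gives 19 mL.min-1.g-1. Compound 3 thus holds the middle place of the three numbers, but it lies within the scatter of both others, so this placing carries little weight.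

Compound 4 `COc1ccc(-c2cc(C(O)(C(F)(F)F)C(F)(F)F)cnc2N2CCN(S(=O)(=O)c3ccc(N)nc3)CC2)cn1` has yet to be measured. It carries 6-methoxypyridin-3-yl in place of 5-fluoropyridin-3-yl on an aromatic carbon, ortho to a large group: 6-methoxypyridin-3-yl in place of 5-fluoropyridin-3-yl on an aromatic carbon.

Among the compounds with values here, no measured step shows this exact exchange. The closest evidence comes from three exchanges at the same place: a 1.7-fold lower number from compound 1 to compound 3 (0.23 log units; within the scatter), a 2.0-fold lower number from compound 1 to compound 2 (0.30 log units; within the scatter) and a 1.2-fold higher number from compound 2 to compound 3 (0.07 log units; within the scatter). All three lie within the scatter, and the last, which also replaces one larger group with another, is the smallest. Across compounds 1, 2 and 3, then, no exchange at this place has moved the number beyond the scatter, and none of the three goes against this. Three compounds are a thin basis, but no step beyond the scatter is expected here.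

The expected result is a 1.1-fold higher number from compound 3 to compound 4 (0.04 log units; within the scatter), with no firm direction implied. The estimated value for compound 4 is 21 mL.min-1.g-1, with an expected range from 11 mL.min-1.g-1 to 38 mL.min-1.g-1.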

Compound 4, intrinsic clearance in microsomes: 265 mL.min-1.g-1
The estimate for compound 4 lay 13-fold (1.10 log units) below the measured number; measured number outside the range, above it.
By their numbers in this assay, from the lowest: compounds 2, 3 and 1 (each within the scatter of the next); then compound 4.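

In this assay this position, on an aromatic carbon ortho to a large group, had so far shown no step beyond the scatter among bromo, 3-hydroxy-3-methylbut-1-yn-1-yl and 5-fluoropyridin-3-yl, but the entry of 6-methoxypyridin-3-yl gives a 14-fold higher number from compound 3 to compound 4 (1.14 log units; beyond the scatter) and also a 17-fold higher number from compound 2 to compound 4 (1.22 log units; beyond the scatter) as well as an 8.3-fold higher number from compound 1 to compound 4 (0.92 log units; beyond the scatter) in the same series. The position is therefore not indifferent to what it carries, and the change between two pyridin-3-yl groups, each a single six-membered aromatic ring with one hetero atom, moves the number further than the change from bromo to either of the other two groups did, so compound 4 stands apart from compounds 1, 2 and 3 on the side of faster removal. Nothing shown here gives a measured reason for this rise.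

The compounds shown do not separate the loss of the fluorine from the entry of the methoxy group, since both differ together between compound 3 and compound 4. As far as these compounds go, whether a hydroxy group, an ethoxy chain or an amine in place of that methoxy group would give a number near that of compound 4 also stays open.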